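Aryl triazole esters of a terpenoid core: untested methoxyphenyl analogue

The source may report more compounds than this note shows. Statements on the series, on what has been measured and on what is new or still open speak of the compounds shown alone.

Compound 1 `C/C(=C\CC/C(C)=C/CC[C@@H]1[C@@]2(C)CCC(=O)C(C)(C)[C@H]2CC[C@@]1(C)O)CC/C=C(\C)C(=O)OCc1cn(-c2ccc([N+](=O)[O-])cc2)nn1` carries a 4-nitrophenyl on the triazole nitrogen. In a functional assay on A549 cells (Homo sapiens) for antiproliferative activity, read by MTT assay, with a stated time of 48 h (a higher number here means a weaker inhibitor, a lower number a stronger inhibitor), compound 1 gives > 150000 nM, which is a limit of the assay and not a number. Compound 2 `C/C(=C\CC/C(C)=C/CC[C@@H]1[C@@]2(C)CCC(=O)C(C)(C)[C@H]2CC[C@@]1(C)O)CC/C=C(\C)C(=O)OCc1cn(-c2ccc(F)c(Cl)c2)nn1` gives in this assay > 150000 nM, again a limit. Compound 3 `C/C(=C\CC/C(C)=C/CC[C@@H]1[C@@]2(C)CCC(=O)C(C)(C)[C@H]2CC[C@@]1(C)O)CC/C=C(\C)C(=O)OCc1cn(-c2cccc(Br)c2)nn1` gives in this assay > 150000 nM, also a limit. Where compound 1 stands among these is therefore not readable: the limit of > 150000 nM in this assay, at which 3 of the 3 values shown sit, describes the whole set. The step that the two limits leave unreadable from compound 1 to compound 2 cannot be sized, nor can a step that the two limits leave unreadable from compound 1 to compound 3 or a step that the two limits leave unreadable from compound 2 to compound 3.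

Compound 4 `COc1ccc(-n2cc(COC(=O)/C(C)=C/CC/C(C)=C/CC/C(C)=C/CC[C@@H]3[C@@]4(C)CCC(=O)C(C)(C)[C@H]4CC[C@@]3(C)O)nn2)cc1` differs from compound 1 by methoxy in place of nitro on an aromatic carbon. None of the three measured steps bears directly on a methoxy for nitro change, and all of them are unreadable because the values sit at the limit, so no direction can be drawn for this assay. Within the data shown here, the only guidance is that every aryl variant so far sits at the limit, and a change of the para substituent alone is not expected to move compound 4 beyond the scatter from that position. The estimated step of a number no higher from compound 1 to compound 4 (the limit leaves the size open) is therefore taken as essentially none, with a high chance of another limit.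

Compound 4 is expected to give in this assay about 150000 nM, within 60000 nM to 400000 nM.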

Compound 4, half-maximal inhibitory concentration: > 150000 nM
Compound 4 ended at the assay's limit (the forecaster's own chance of this, stated with the estimate: 75%); the middle value lies on the limit itself.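

In this assay compound 4 gives > 150000 nM as a limit of the assay and not a number. Among these compounds, no step between compound 4 and compound 1, compound 2 or compound 3 can be read, and one limit covers the whole set: the limit of > 150000 nM in this assay, at which 4 of the 4 values shown sit. The compounds shown leave open whether any aryl group on the triazole nitrogen gives a measurable value, and how these four rank.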